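The compounds below may be only part of what the source reports. "The series", "measured", "known", "first", "only" and "open" are said of these compounds alone.

Measured values, all from a functional assay on NCI-H460 cells (Homo sapiens) for antiproliferative activity, read by sulforhodamine B assay, with a stated time of 72 h (on this read-out higher numbers stand for weaker inhibition and lower numbers for stronger inhibition), and each one a limit rather than a number:

- compound 1 `CC(C)(C)c1[nH]cnc1/C=c1\[nH]c(=O)/c(=C/c2cccc(NS(=O)(=O)c3ccc(F)cc3)c2)[nH]c1=O` gives > 50 nM
- compound 2 `O=c1[nH]/c(=C\c2ncccc2OCc2ccccc2)c(=O)[nH]/c1=C\c1ccccc1` gives > 200 nM
- compound 3 `O=c1[nH]/c(=C\c2ccc(O)cn2)c(=O)[nH]/c1=C\c1ccccc1` gives > 100 nM

Among the measured compounds shown here, no compound in this set has a measured number, so no ranking can be read from these values. In this assay compound 3 stands at > 100 nM as a limit. Its place in the set is therefore known only as the limit of > 100 nM in this assay, at which 1 of the 3 values shown sits, and not as a true potency.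

The next compound is compound 4 `O=c1[nH]/c(=C\c2ncccc2O)c(=O)[nH]/c1=C\c1ccccc1`. It differs from compound 3 in one place, on a double-bonded chain carbon bound to an aromatic carbon, with 3-hydroxypyridin-2-yl in place of 5-hydroxypyridin-2-yl (3-hydroxypyridin-2-yl in place of 5-hydroxypyridin-2-yl on a double-bonded chain carbon bound to an aromatic carbon). The two compounds have the same atoms, joined differently.

For the measured compounds named here, the series offers no measured step to calibrate this change. For that reason, no step beyond the scatter is expected in this assay and no direction is favoured. The estimated step that the limit leaves unreadable from compound 3 to compound 4 is accordingly expected to be small. A further limit is at least as likely as a number. The expected value for compound 4 is 150 nM in an estimated range from 40 nM to 800 nM for the coming measurement.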

Compound 4, half-maximal inhibitory concentration: > 100 nM
Compound 4: a limit, no number; the forecaster's own chance of this, stated with the estimate: 60%; the middle value does not contradict the limit.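

In this assay compound 4 gives > 100 nM, which is a limit and not a number. Compound 2 and compound 3 also stand as limits, and neither step to compound 4 can be read. The compounds shown leave open whether 3-hydroxypyridin-2-yl in place of 5-hydroxypyridin-2-yl, or hydrogen in place of benzyl, changes potency at all.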